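This account rests on a few compounds, and the source may have more. Where it says the series, first, only, none or still open, it means among the compounds named here.

Compound 3, `Cc1ccc(OCC(=O)N(Cc2cccs2)c2ccccc2)cc1`, belongs to a set of three amides that share one core and differ only in the group attached to the amide-type nitrogen. In an assay on HEK293 cells for agonist activity at transient receptor potential cation channel subfamily M member 8 (Homo sapiens), read by fluorescence and calcium flux, with a stated time of 15 min (on this read-out higher numbers stand for an effect only at larger amounts of compound and lower numbers for an effect already at smaller amounts), compound 3 gives 23 nM, which is the second highest of the three numbers. Compound 1, `Cc1ccc(OCC(=O)N(Cc2cccs2)C2CC2)cc1`, carries a cyclopropyl at that nitrogen and gives 8 nM, so a 2.9-fold higher number from compound 1 to compound 3 (0.46 log units; beyond the scatter). Compound 2, `Cc1ccc(OCC(=O)N(Cc2cccs2)c2nccs2)cc1`, carries a 1,3-thiazol-2-yl there and gives 2240 nM; accordingly a 280-fold higher number from compound 1 to compound 2 (2.45 log units; beyond the scatter) and a 97-fold lower number from compound 2 to compound 3 (1.99 log units; beyond the scatter).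

Compound 4, `Cc1ccc(OCC(=O)N(Cc2cccs2)c2ccccn2)cc1`, has not yet been measured. It differs from compound 3 in a single place: pyridin-2-yl in place of phenyl on an amide-type nitrogen. The step from compound 2 to compound 3 bears most directly on this change, since it too exchanges phenyl against an aromatic ring with a hetero atom at the same position, and that step was large. The step from compound 1 to compound 3 was modest. For the measured compounds named here, no measured compound shows how a pyridin-2-yl itself behaves, so the expectation is a higher number for compound 4 than for compound 3, though probably a smaller move than the one seen with 1,3-thiazol-2-yl. Compound 4 is therefore estimated at 200 nM, within 40 nM to 1500 nM, an expected 8.7-fold higher number from compound 3 to compound 4 (0.94 log units; beyond the scatter).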

Compound 4, half-maximal effective concentration: 200 nM
The estimate for compound 4 equals the measured number at the digits printed; the range from low to high includes it.
By their numbers in this assay, from the lowest: compound 1; then compound 3; then compound 4; then compound 2.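

Exchanging phenyl for pyridin-2-yl keeps a six-membered aromatic ring and the same count of heavy atoms, changing one ring carbon to nitrogen and adding one hydrogen-bond acceptor, yet in this assay this single exchange gives an 8.7-fold higher number from compound 3 to compound 4 (0.94 log units; beyond the scatter) on the amide-type nitrogen. The higher number seen with 1,3-thiazol-2-yl is thus not unique to that ring, although the two hetero-atom rings are far from equivalent, with an 11-fold lower number from compound 2 to compound 4 (1.05 log units; beyond the scatter) in this series, and the non-aromatic cyclopropyl keeps the lowest number of the four, with a 25-fold higher number from compound 1 to compound 4 (1.40 log units; beyond the scatter) marking its distance from the pyridin-2-yl compound. No measurement offered here explains why one ring nitrogen moves the number this far.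

The compounds shown leave open where a pyrimidinyl ring, with a second ring nitrogen, would fall among these four numbers. They also leave open whether a larger saturated ring such as cyclohexyl, or an open chain such as ethyl, would stay close to cyclopropyl at this amide-type nitrogen or move towards the aromatic rings.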